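Ester Variation on a Shared Core Against Breast Cancer Cells

A few compounds are considered here, and "the series" means these few. Any claim that something is new, unique, unknown or untested is made for them only; others in the source may bear on it.

Measured compounds:
compound 1 `CC(C)(CCl)C(=O)Oc1ccc(Cn2ccnc2)c2cccnc12` — 12400 nM
compound 2 `CC(C)(C)OC(=O)Oc1ccc(Cn2c(-c3cscn3)nc3ccccc32)c2cccnc12` — "not determined" (no result reported)
compound 3 `Cc1ccc2c(Cn3cnc(F)c3)ccc(OC(=O)OC(C)(C)C)c2n1` — 2700 nM

In a functional assay on MDA-MB-231 cells (Homo sapiens) for antiproliferative activity, read by luminescence, with a stated time of 72 h (on this read-out higher numbers stand for weaker inhibition and lower numbers for stronger inhibition), compound 1 gives 12400 nM, the highest of the two numbers in hand; compound 3 gives 2700 nM, a lower number by a gap beyond the scatter. Compound 2 has no result in this assay, reported as "not determined" (no result reported). Compound 4 `O=C(Oc1ccc(Cn2ccnc2)c2cccnc12)c1ccccc1` differs from compound 1 by a single change: phenyl in place of 1-(chloromethyl)-1-methylethyl on a carbonyl carbon. Going by the values given here, no measured pair shows this change, so the size of the step is open. Compound 4 is expected to stay close to compound 1, with a step of a 1.6-fold lower number from compound 1 to compound 4 (0.19 log units; within the scatter) in this assay. The estimate for compound 4 is 8000 nM, with a range from 2500 nM to 25000 nM.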

Compound 4, half-maximal inhibitory concentration: 12300 nM
For compound 4 the middle estimate is 1.5-fold (0.19 log units) below the measured one; the measured number falls inside the stated range.
By their numbers in this assay, from the lowest: compound 3; then compounds 4 and 1 (each within the scatter of the next).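

Going by these compounds alone, putting phenyl in place of 1-(chloromethyl)-1-methylethyl on a carbonyl carbon gives the first measured step at this position: in this assay it is a 1.0-fold lower number from compound 1 to compound 4 (0.00 log units; within the scatter). This position therefore holds a group without a ring and a six-membered aromatic ring of carbon only at the same level in this assay. Nothing measured here bears on why the two groups read alike.

From the compounds shown here alone, whether an amine, a carboxylic acid or a longer chain on this carbonyl carbon would also leave the number in place remains open. Compound 3 differs from both compounds in more than one place, so its lower number cannot be tied to this position.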